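The source may hold more compounds than are shown below. What is called first, only, known or untested is meant among the compounds shown, and "the series" means these compounds.

The measured compounds are compound 1, `O=C(O)Cc1sc(C(c2ccccc2)c2ccc(F)cc2)nc1-c1ccc(Cl)cc1`, with 17 nM in an in vitro assay on HEK385-7 cells for displacement of a labelled ligand from prostaglandin D2 receptor 2 (Homo sapiens); on this read-out lower numbers stand for stronger inhibition and higher numbers for weaker inhibition; compound 2, `O=C(O)Cc1sc(C(c2ccc(F)cc2)c2ccc(F)cc2)nc1-c1ccc(Cl)cc1`, with 9.7 nM; and compound 3, `O=C(O)Cc1sc(C(c2ccccc2)c2ccccc2)nc1-c1ccccc1`, with 570 nM.

Compound 1 and compound 2 differ by one change, (fluoro in place of hydrogen on an aromatic carbon). This change gave a 1.8-fold lower number from compound 1 to compound 2 (0.24 log units; within the scatter), so on the shared core of these two compounds it left the number essentially where it was.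

Compound 3 stands apart from compound 1 and compound 2 in several places at once, and the difference between the two cores is not broken down here; what the values show is that compound 3 gives the highest number of the three, beyond the scatter from each of the other two.

Compound 4, `O=C(O)Cc1sc(C(c2ccccc2)c2ccccc2)nc1-c1ccc(F)cc1`, has not yet been measured. It is related to compound 3 by fluoro in place of hydrogen on an aromatic carbon. Going by the values given here, this is the same change as the one from compound 1 to compound 2, and it sits in the same kind of place, though here on the core of compound 3 rather than the core of compound 1.

Among the compounds with values here, for compound 4 a step of about a 1.7-fold lower number from compound 3 to compound 4 (0.24 log units; within the scatter) is expected, resting on the size of a 1.8-fold lower number from compound 1 to compound 2 (0.24 log units; within the scatter), which was small and within the scatter; with only one earlier example, on a different core, the expected step is held loose. Compound 4 is therefore estimated at 330 nM, with a range from 110 nM to 900 nM.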

Compound 4, half-maximal inhibitory concentration: 8.7 nM
The estimate for compound 4 lay 38-fold (1.58 log units) above the measured number; measured number outside the range, below it.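

Fluoro in place of hydrogen on an aromatic carbon gave a 66-fold lower number from compound 3 to compound 4 (1.82 log units; beyond the scatter) in this assay, so the change that left the number essentially where it was on the core of compound 1 had a large effect on the core of compound 3, and the two steps differ by more than the scatter allows: the same change on two cores in this assay, a 1.8-fold lower number (0.24 log units; within the scatter) from compound 1 to compound 2 and a 66-fold lower number (1.82 log units; beyond the scatter) from compound 3 to compound 4, 37-fold (1.57 log units) apart, beyond the scatter of two such steps

This shows that in this series the size of the step does not carry from one core to the other, so a small step on one core gives no safe estimate of the step on another. It does not show which of the several differences between the two cores sets the size of the step, and two pairs of compounds give no general rule for other cores or explain the gap.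

The compounds shown leave open whether another group on the core of compound 3, such as chloro's untested neighbours methyl, methoxy or trifluoromethyl in place of the same hydrogen, would give a step as large as fluoro does. They also leave open how the step would behave on a core carrying an amide or a longer chain in place of the acetic acid side chain.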